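Configuration flip at one stereocentre: compound 3 to compound 4

This account rests on a few compounds, and the source may have more. Where it says the series, first, only, none or still open, it means among the compounds named here.

compound 1 `C[C@]1(c2ccc(OC(F)(F)F)cc2)C[C@@](O)(c2ccccn2)CO1` gives 117 mL/min/kg here
compound 2 `C[C@@]1(c2ccc(OC(F)(F)F)cc2)C[C@@](O)(c2ccccn2)CO1` gives 66.7 mL/min/kg here
compound 3 `C[C@@]1(c2ccc(OC(F)(F)F)cc2)C[C@](O)(c2ccccn2)CO1` gives 217 mL/min/kg here
compound 4 `C[C@]1(c2ccc(OC(F)(F)F)cc2)C[C@](O)(c2ccccn2)CO1` is not yet measured

All numbers come from an ADME assay on liver for metabolic stability, with Liver microsome (Homo sapiens) as the target, read by LC-MS, using microsomes, with a stated time of 5 h (on this read-out higher numbers stand for fast clearance and lower numbers for slow clearance), and the compounds differ only in configuration as drawn. For compound 3, one gap lies beyond the scatter (a 3.3-fold higher number from compound 2 to compound 3 (0.51 log units; beyond the scatter)) and the other lies within it (a 1.9-fold higher number from compound 1 to compound 3 (0.27 log units; within the scatter)).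

The next change is a single inversion (the two compounds have the same atoms and bonds and differ only in configuration as drawn: 1 of 2 stereo elements differ; a stereocentre at a saturated ring carbon is drawn S in compound 3 and R in compound 4) and no group leaves or enters. Compound 4 has the R drawing of compound 1 at that centre, while compound 3 has the S drawing of compound 2. Within the data shown here, the closest precedent is therefore the step (a 1.8-fold lower number from compound 1 to compound 2 (0.24 log units; within the scatter)) run in reverse, and that step lies within the scatter. Among the measured compounds shown here, the other centre stays as drawn in compound 3, where inversion gave the only larger step (a 3.3-fold higher number from compound 2 to compound 3 (0.51 log units; beyond the scatter)), so that step is not repeated here. Taking the precedent from compound 1 in reverse, a number somewhat higher is expected, but no step beyond the scatter is expected (a 1.2-fold higher number from compound 3 to compound 4 (0.09 log units; within the scatter)). In this assay compound 4 is estimated at 270 mL/min/kg within the expected range (130 mL/min/kg to 520 mL/min/kg).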

Compound 4, clearance: 117 mL/min/kg
Beside the measured number, compound 4's estimate is 2.3-fold (0.36 log units) above it; measured number outside the range, below it.
By their numbers in this assay, from the lowest: compounds 2, 1, 4 and 3 (each within the scatter of the next, the first and the last beyond it).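

In this assay, inverting this centre from the compound 3 drawing gives a 1.9-fold lower number from compound 3 to compound 4 (0.27 log units; within the scatter), so this inversion now stays within the scatter on both drawings of the other centre, as it did in a 1.8-fold lower number from compound 1 to compound 2 (0.24 log units; within the scatter). The other centre now has a second reading, no change at the digits printed from compound 1 to compound 4 (within the scatter), and this sits against a 3.3-fold higher number from compound 2 to compound 3 (0.51 log units; beyond the scatter), the same inversion made with this centre in the opposite drawing, so the size of that inversion depends on how this centre is drawn. The second mirror-image pair, a 1.8-fold higher number from compound 2 to compound 4 (0.24 log units; within the scatter), also lies within the scatter, as does a 1.9-fold higher number from compound 1 to compound 3 (0.27 log units; within the scatter), which leaves the gap between compound 2 and compound 3 as the only one of the six beyond it.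

That single gap rests on one reading per compound, and the four stereoisomers alone do not show what lies behind it. Going by these compounds, whether the dependence between the two centres survives a change of group stays open, for example an amine in place of the hydroxyl or a carboxylic acid on the shared core.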